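A few compounds are considered here, and "the series" means these few. Any claim that something is new, unique, unknown or untested is made for them only; others in the source may bear on it.

Compound 1 `O=C(COc1cccc2ccccc12)N/N=C/c1ccc(Cl)cc1` is the reference point of this series. In a physicochemical assay for lipophilicity, measured as octanol-water partition (on this read-out higher numbers stand for higher lipophilicity and lower numbers for lower lipophilicity), compound 1 gives 4.54, the highest of the two numbers available, and its nearest neighbour is compound 2 `O=C(COc1cccc2ccccc12)N/N=C/c1ccc([N+](=O)[O-])cc1`, which in this assay gives 3.97. Among the measured compounds shown here, the only measured step, nitro in place of chloro on an aromatic carbon, is a number 0.57 log units lower from compound 1 to compound 2 (beyond the scatter). Compound 3 `O=C(COc1cccc2ccccc12)N/N=C/c1cccc(Br)c1` differs from compound 1 as follows: 3-bromophenyl in place of 4-chlorophenyl on a carbon with a double bond to nitrogen. For the measured compounds named here, no measured step bears directly on a swap of one halogen for another, nor on the move of the substituent to a different position on the ring, so the step from compound 1 to compound 2 offers no close guide here. On the structural change alone, a small rise in this assay is expected, a number 0.21 log units higher from compound 1 to compound 3 (within the scatter), within or just beyond the scatter. Compound 3 is therefore estimated at 4.75, with a range from 4.45 to 5.05.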

Compound 3, partition coefficient: 4.81
Compound 3: the middle estimate sits 0.06 log units below what was measured; the measured number falls inside the stated range.
By their numbers in this assay, from the lowest: compound 2; then compounds 1 and 3 (each within the scatter of the next).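

In this assay, 3-bromophenyl in place of 4-chlorophenyl on a carbon with a double bond to nitrogen gives a number 0.27 log units higher from compound 1 to compound 3 (within the scatter), so unlike the nitro for chloro step, this exchange does not separate the two compounds on this read-out. The halogen and its place on the ring change together while the heavy-atom count of the group stays the same, and this single pair cannot tell the two changes apart. Nothing in the available evidence accounts for the result.

The compounds shown leave open how 4-bromophenyl or 3-chlorophenyl would read against this pair, which would separate the halogen from its place on the ring. They also leave open how an amine, a carboxylic acid or a methoxy group on the same phenyl ring would read in this assay.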